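A few compounds are considered here, and "the series" means these few. Any claim that something is new, unique, unknown or untested is made for them only; others in the source may bear on it.

Measured in a functional assay on RS4-11 cells (Homo sapiens) for inhibition, read by CCK-8 assay, with a stated time of 48 h; a higher number here means a weaker inhibitor, a lower number a stronger inhibitor:
- Compound 1 `O=C(NCCNS(=O)(=O)c1sccc1-c1ccccc1Oc1ccc(O)c(O)c1)Nc1cc(C(F)(F)F)cc(C(F)(F)F)c1`: 4900 nM
- Compound 2 `CC(C)c1ccc(Oc2ccc(O)c(O)c2)c(-c2ccsc2S(=O)(=O)NCCNC(=O)Nc2cc(C(F)(F)F)cc(C(F)(F)F)c2)c1`: 6800 nM

Compound 2, at 6800 nM, lies within the scatter of compound 1, so neither can be ranked above the other. Compound 3 `COc1ccc(Oc2ccc(C(C)C)cc2-c2ccsc2S(=O)(=O)NCCNC(=O)Nc2cc(C(F)(F)F)cc(C(F)(F)F)c2)cc1OC` keeps the rest of compound 2 but has 3,4-dimethoxyphenyl in place of 3,4-dihydroxyphenyl on an oxygen on an aromatic ring. Among the measured compounds shown here, the single measured step, a 1.4-fold higher number from compound 1 to compound 2 (0.14 log units; within the scatter), is an isopropyl for hydrogen swap elsewhere in the molecule and stays within the scatter. For the measured compounds named here, it therefore says little here, and no measured compound shows what this change does. With no evidence for a shift in either direction, the expected step is small: a 1.2-fold higher number from compound 2 to compound 3 (0.07 log units; within the scatter), which is no change beyond the scatter. For compound 3 the estimated value is 8000 nM, with an expected range of 2500 nM to 25000 nM.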

Compound 3, half-maximal inhibitory concentration: 11700 nM
The estimate for compound 3 lay 1.5-fold (0.17 log units) below the measured number; measured number inside the range.
By their numbers in this assay, from the lowest: compounds 1, 2 and 3 (each within the scatter of the next, the first and the last beyond it).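

Compound 2 and compound 3 are the only pair shown that tests this position, the aromatic ring carried on the oxygen. In this assay, exchanging 3,4-dihydroxyphenyl for 3,4-dimethoxyphenyl gives a 1.7-fold higher number from compound 2 to compound 3 (0.24 log units; within the scatter). The two hydrogen-bond donors of the 3,4-dihydroxyphenyl group can therefore be replaced by a group with none without a step beyond the scatter, and no supporting measurement is available to explain this reading.

The compounds shown leave open whether a ring carrying a single hydroxyl, a single methoxy, an amine or a carboxylic acid would move the number beyond the scatter. They also leave open whether the same exchange would read alike on the core of compound 1, which lacks the isopropyl group.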